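Methoxy for nitro on a trimethoxyphenyl-imidazolone series

The source may hold more compounds than are shown below. What is called first, only, known or untested is meant among the compounds shown, and "the series" means these compounds.

Measured compounds and their values:
- Compound 1 `COc1ccc(-c2c[nH]c(=O)n2-c2cc(OC)c(OC)c(OC)c2)cc1OC`: 38800 nM
- Compound 2 `COc1ccc(-c2c[nH]c(=O)n2-c2cc(OC)c(OC)c(OC)c2)cc1[N+](=O)[O-]`: 14300 nM
- Compound 3 `COc1cc(-n2c(-c3ccc([N+](=O)[O-])cc3)cn(C(C)=O)c2=O)cc(OC)c1OC`: 7200 nM

All three were tested in a functional assay on HL-60 cells (Homo sapiens) for cytotoxicity, read by MTT assay, with a stated time of 48 h; on this read-out higher numbers stand for weaker inhibition and lower numbers for stronger inhibition. Compound 3 gives the lowest of the three numbers; its gap to compound 2 lies within the scatter, while its gap to compound 1 lies beyond it. The difference between the core of compound 3 and the core of compound 2 is not broken down here.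

Within the data shown here, the one change that is seen twice is this: from compound 2 to compound 1 (methoxy in place of nitro on an aromatic carbon), which made a step of a 2.7-fold higher number from compound 2 to compound 1 (0.43 log units; beyond the scatter). Compound 4 `COc1ccc(-c2cn(C(C)=O)c(=O)n2-c2cc(OC)c(OC)c(OC)c2)cc1` has not yet been measured; it arises from compound 3 by methoxy in place of nitro on an aromatic carbon. This is the same kind of change, but not the same: in the first case the place is ortho to a methoxy group and meta to a large group, in the second it is para to a large group.

Compound 4 is expected to sit at 19000 nM, between 8000 nM and 50000 nM, because compound 2 going to compound 1 gave a 2.7-fold higher number from compound 2 to compound 1 (0.43 log units; beyond the scatter). This estimate means a step of a 2.6-fold higher number from compound 3 to compound 4 (0.42 log units; beyond the scatter).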

Compound 4, half-maximal inhibitory concentration: 5500 nM
Compound 4: the middle estimate sits 3.5-fold (0.54 log units) above what was measured, and the stated range ends above it.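

In this assay, putting methoxy in place of nitro on the core of compound 3 gives a 1.3-fold lower number from compound 3 to compound 4 (0.12 log units; within the scatter), so on this core the change moves the number no further than repeated measurements would. Set beside the earlier step, the same change does not carry over in size from one core to the other: the same change on two cores in this assay, a 2.7-fold higher number (0.43 log units; beyond the scatter) from compound 2 to compound 1 and a 1.3-fold lower number (0.12 log units; within the scatter) from compound 3 to compound 4, 3.6-fold (0.55 log units) apart, beyond the scatter of two such steps This does not show that the core alone sets the gap, since the two pairs also differ in where the change sits on the aromatic ring, and two steps can neither separate these influences nor give a rule for the whole series.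

Still open, from the compounds shown here alone, is how an amine or a carboxylic acid in the place of the nitro would read on each core. Also open, going by these compounds, is whether the same change on a further core would resemble either of these two steps.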